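The source may report more compounds than this note shows. Statements on the series, on what has been measured and on what is new or still open speak of the compounds shown alone.

Measured compounds in the series:
compound 1 `CC1=CC[C@H](C(C)(C)NC(=S)N/N=C(\C)c2ccccc2)CC1` — 20700 nM
compound 2 `COc1ccc(/C(C)=N/NC(=S)NC(C)(C)[C@H]2CC=C(C)CC2)cc1` — 5000 nM

In a functional assay on MCF7 cells (Homo sapiens) for inhibition, read by sulforhodamine B assay, with a stated time of 48 h (on this read-out lower numbers stand for stronger inhibition of growth and higher numbers for weaker inhibition of growth), compound 2 gives 5000 nM, the lower of the two numbers; compound 1 gives 20700 nM. Among the measured compounds shown here, the single measured step, a 4.1-fold lower number from compound 1 to compound 2 (0.62 log units; beyond the scatter), is modest but beyond the scatter. Compound 3 `CC1=CC[C@H](C(C)(C)NC(=S)N/N=C(\C)c2ccc([N+](=O)[O-])cc2)CC1` differs from compound 2 by nitro in place of methoxy on an aromatic carbon. For the measured compounds named here, no measured step covers an exchange of methoxy for nitro; the step from compound 1 to compound 2 only shows that a substituent at this carbon shifts the read-out. Compound 3 is therefore expected near 8000 nM, within 2500 nM to 30000 nM, an estimated step of a 1.6-fold higher number from compound 2 to compound 3 (0.20 log units; within the scatter) that may not exceed the scatter.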

Compound 3, concentration for 50% growth inhibition: 8000 nM
Beside the measured number, compound 3's estimate shows no gap at the digits printed, within the range that was stated.
By their numbers in this assay, from the lowest: compounds 2 and 3 (each within the scatter of the next); then compound 1.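

In this assay the exchange of methoxy for nitro gives a 1.6-fold higher number from compound 2 to compound 3 (0.20 log units; within the scatter), so these two groups are not separated at this aromatic carbon. Nitro in place of hydrogen gives a 2.6-fold lower number from compound 1 to compound 3 (0.41 log units; beyond the scatter), which means that a second substituent, not only methoxy, departs from the unsubstituted compound 1 at this carbon. No supporting data bear on why the two groups read alike. On these data alone, whether an amine or a carboxylic acid at this carbon would also fall with compound 2 and compound 3 remains open.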